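Trimming the amine side chain of compound 2

The source may hold more compounds than are shown below. What is called first, only, known or untested is meant among the compounds shown, and "the series" means these compounds.

Measured so far:
compound 1 `COc1cc(OC)c(C(=O)/C=C/c2ccccc2Cl)c(O)c1CN(C)CC(=O)O`: 35200 nM
compound 2 `COc1cc(OC)c(C(=O)/C=C/c2ccccc2Cl)c(O)c1CN(C)CCCN(C)C`: 30900 nM

Going by the values given here, in a functional assay on Bel-7402 cells (Homo sapiens) for antiproliferative activity, with a stated time of 72 h (a higher number here means a weaker inhibitor, a lower number a stronger inhibitor), compound 2 stands at 30900 nM and cannot be told apart from compound 1, the only other compound measured. Compound 3 `COc1cc(OC)c(C(=O)/C=C/c2ccccc2Cl)c(O)c1CN(C)C` carries hydrogen in place of 2-(dimethylamino)ethyl on a saturated chain carbon bound to an amine nitrogen. Among the compounds with values here, one measured step bears on this, a change at the same place: a 1.1-fold lower number from compound 1 to compound 2 (0.06 log units; within the scatter). Within the data shown here, no measured compound yet shows this chain cut back, so that single step is thin evidence. Even so, the expectation is a step that stays within the scatter, with no direction favoured. The expected step is a 1.1-fold lower number from compound 2 to compound 3 (0.04 log units; within the scatter). For compound 3 the estimated value is 28000 nM, with an expected range of 12000 nM to 60000 nM.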

Compound 3, half-maximal inhibitory concentration: 21800 nM
The estimate for compound 3 lay 1.3-fold (0.11 log units) above the measured number, within the range that was stated.
By their numbers in this assay, from the lowest: compounds 3, 2 and 1 (each within the scatter of the next).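

Hydrogen in place of 2-(dimethylamino)ethyl (a 1.4-fold lower number from compound 2 to compound 3 (0.15 log units; within the scatter)) and hydrogen in place of carboxy (a 1.6-fold lower number from compound 1 to compound 3 (0.21 log units; within the scatter)) both stay within the scatter in this assay and so extend the earlier finding. On a saturated chain carbon bound to an amine nitrogen, the bare hydrogen of compound 3 cannot be told apart from either longer substituent, so neither the carboxy of compound 1 nor the 2-(dimethylamino)ethyl of compound 2 is shown to matter for this read-out. No measurement given here explains why these numbers sit so close together.

As far as these compounds go, whether any substituent at this place can move the number beyond the scatter remains open. A piperidine or morpholine ring on the amine nitrogen, a primary amine, or a much longer alkyl chain could each answer that.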